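Methyl on nitrogen: one measured step, one to come

This account rests on a few compounds, and the source may have more. Where it says the series, first, only, none or still open, it means among the compounds named here.

Compound 1 `CNc1nc(NCc2ccc(NC(C)=O)cc2)cc(-c2ccccn2)n1` gives 2 nM in a functional assay on HEK293 cells for agonist activity at G-protein coupled receptor 39 (Mus musculus), read by inositol phosphate accumulation; on this read-out lower numbers stand for an effect already at smaller amounts and higher numbers for an effect only at larger amounts of compound. Compound 2 `CNc1nc(NCc2ccc(N(C)C(C)=O)cc2)cc(-c2ccccn2)n1` gives 2610 nM in this assay. The change from compound 1 to compound 2 is methyl in place of hydrogen on an amide-type nitrogen; it made a 1300-fold higher number from compound 1 to compound 2 (3.12 log units; beyond the scatter). Compound 3 `CNc1nc(NCC2CC2)cc(-c2ccccn2)n1` gives 115 nM in this assay; how its core differs from the core of compound 1 is not broken down here, and its number sits between those of compound 1 and compound 2, beyond the scatter from each.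

Compound 4 `CN(C)c1nc(NCC2CC2)cc(-c2ccccn2)n1` is not yet measured. It differs from compound 3 by methyl in place of hydrogen on a nitrogen on an aromatic ring. This is the same kind of change as that from compound 1 to compound 2, not the same one: there the methyl entered on an amide-type nitrogen whose other neighbours are aromatic carbon and carbonyl carbon, here on a nitrogen on an aromatic ring whose other neighbours are aromatic carbon and saturated chain carbon. Resting on a 1300-fold higher number from compound 1 to compound 2 (3.12 log units; beyond the scatter), discounted for the changed place, the expected step is a 10-fold higher number from compound 3 to compound 4 (1.02 log units; beyond the scatter). Compound 4 is estimated at 1200 nM in this assay, with a range from 200 nM to 8000 nM.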

Compound 4, half-maximal effective concentration: 6720 nM
For compound 4 the middle estimate is 5.6-fold (0.75 log units) below the measured one, and the stated range covers the measured number.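

Methyl in place of hydrogen on a nitrogen gave a 58-fold higher number from compound 3 to compound 4 (1.77 log units; beyond the scatter) in this assay, so on these two cores the change moves the number the same way, and a large step on one core went with a large step on the other. The direction carried over, but the size did not: the same change on two cores in this assay, a 1300-fold higher number (3.12 log units; beyond the scatter) from compound 1 to compound 2 and a 58-fold higher number (1.77 log units; beyond the scatter) from compound 3 to compound 4, 22-fold (1.35 log units) apart, beyond the scatter of two such steps
These two pairs do not show whether that gap follows from the different core or from the different place of the methyl, since the amide-type nitrogen and the nitrogen on an aromatic ring change together with the core, and they give no rule for any further core in the series.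

Still open, as far as these compounds go, is what methylamino to dimethylamino does on the core of compound 1, which would set the place of the methyl apart from the rest of the core. Equally open, from the compounds shown here alone, is whether ethyl or a longer chain on the same nitrogen gives a step of similar size.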